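Removing the methoxy group from the core of compound 3

The source may report more compounds than this note shows. Statements on the series, on what has been measured and on what is new or still open speak of the compounds shown alone.

Measured so far:
compound 1 `COc1ccc(-c2[nH]c3ccccc3c2/C=C(\C#N)S(=O)(=O)c2ccccc2)cc1`: 1000 nM
compound 2 `CC(=O)/C(=C\c1c(-c2ccccc2)[nH]c2ccccc12)S(=O)(=O)c1ccccc1`: 1200 nM
compound 3 `COc1ccc2[nH]c(-c3ccccc3)c(/C=C(\C#N)S(=O)(=O)c3ccccc3)c2c1`: 8300 nM

In a functional assay on HOP-62 cells (Homo sapiens) for inhibition, read by sulforhodamine B assay, with a stated time of 48 h (a lower number here means a stronger inhibitor of growth, a higher number a weaker inhibitor of growth), compound 3 gives 8300 nM, the highest of the three numbers; compound 2 gives 1200 nM and compound 1 gives 1000 nM, both beyond the scatter from compound 3, so compound 3 is the weakest inhibitor of growth among the three. Compound 4 `N#C/C(=C\c1c(-c2ccccc2)[nH]c2ccccc12)S(=O)(=O)c1ccccc1` differs from compound 3 in one place: hydrogen in place of methoxy on an aromatic carbon. For the measured compounds named here, no single-change step between measured compounds covers this change. Compounds 1 and 2 lack a methoxy on the fused system of two rings and both sit well below compound 3, so a drop toward their values is expected. The expected step is a 5.5-fold lower number from compound 3 to compound 4 (0.74 log units; beyond the scatter). Compound 4 is estimated at 1500 nM, within 500 nM to 5000 nM.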

Compound 4, concentration for 50% growth inhibition: 9300 nM
Compound 4: middle estimate off by 6.2-fold (0.79 log units), on the low side; the measured number lies above the stated range.
By their numbers in this assay, from the lowest: compounds 1 and 2 (each within the scatter of the next); then compounds 3 and 4 (each within the scatter of the next).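

In this assay, hydrogen and methoxy on this aromatic carbon of the core are not told apart, with a 1.1-fold higher number from compound 3 to compound 4 (0.05 log units; within the scatter). The larger steps lie elsewhere: cyano in place of acetyl on the chain gives a 7.8-fold higher number from compound 2 to compound 4 (0.89 log units; beyond the scatter), and hydrogen in place of methoxy on a different aromatic carbon, that of the pendant ring, gives a 9.3-fold higher number from compound 1 to compound 4 (0.97 log units; beyond the scatter). Going by these compounds, whether an amine or a carboxylic acid on the core carbon would separate from methoxy and hydrogen remains open. Nothing available explains why these steps differ in size.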